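Cyano in Place of Hydroxy: Expected Cytotoxicity of Compound 4

This account rests on a few compounds, and the source may have more. Where it says the series, first, only, none or still open, it means among the compounds named here.

Measured compounds:
Compound 1 `C[C@H]1CC[C@@H]2[C@@H](OC(=O)[C@]23CC(c2ccc(O)cc2)=NO3)[C@]2(C)C(=O)C=C[C@@]12O` gives 20000 nM in a functional assay on PC-3 cells (Homo sapiens) for cytotoxicity, read by sulforhodamine B assay, with a stated time of 48 h; on this read-out higher numbers stand for weaker inhibition and lower numbers for stronger inhibition.
Compound 2 `C[C@H]1CC[C@@H]2[C@@H](OC(=O)[C@]23CC(c2ccccc2F)=NO3)[C@]2(C)C(=O)C=C[C@@]12O` gives 8200 nM in this assay.
Compound 3 `C[C@H]1CC[C@@H]2[C@@H](OC(=O)[C@]23CC(c2ccc(F)cc2)=NO3)[C@]2(C)C(=O)C=C[C@@]12O` gives 27000 nM in this assay.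

Compound 1 stands second highest of the three numbers; its nearest neighbour is compound 3, with a 1.4-fold higher number from compound 1 to compound 3 (0.13 log units; within the scatter), and its furthest is compound 2, with a 2.4-fold lower number from compound 1 to compound 2 (0.39 log units; beyond the scatter). Compound 4 `C[C@H]1CC[C@@H]2[C@@H](OC(=O)[C@]23CC(c2ccc(C#N)cc2)=NO3)[C@]2(C)C(=O)C=C[C@@]12O` differs from compound 1 in one place: cyano in place of hydroxy on an aromatic carbon. Within the data shown here, the step that bears most directly on this change is the one in which another group took the place of the hydroxy on the same aromatic carbon, and there the number stayed within the scatter: a 1.4-fold higher number from compound 1 to compound 3 (0.13 log units; within the scatter). Among the measured compounds shown here, the one step beyond the scatter, a 3.3-fold higher number from compound 2 to compound 3 (0.52 log units; beyond the scatter), sets 2-fluorophenyl against 4-fluorophenyl rather than exchanging a group on the same carbon, and the same holds for a 2.4-fold lower number from compound 1 to compound 2 (0.39 log units; beyond the scatter). For compound 4 in this assay no step beyond the scatter is therefore expected, no change at the digits printed from compound 1 to compound 4 (within the scatter). The estimate for compound 4 is 20000 nM, with a range from 8000 nM to 50000 nM.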

Compound 4, half-maximal inhibitory concentration: 32000 nM
The estimate for compound 4 lay 1.6-fold (0.20 log units) below the measured number; the range from low to high includes it.
By their numbers in this assay, from the lowest: compound 2; then compounds 1, 3 and 4 (each within the scatter of the next).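

In this assay, cyano at this aromatic carbon, para to a large group, leaves the number within the scatter of hydroxy (a 1.6-fold higher number from compound 1 to compound 4 (0.20 log units; within the scatter)), even though cyano brings no hydrogen-bond donor. Cyano and fluoro at the same carbon also cannot be told apart (a 1.2-fold higher number from compound 3 to compound 4 (0.07 log units; within the scatter)), so hydroxy, fluoro and cyano at this carbon now give numbers within the scatter of one another. Compound 2, with its 2-fluorophenyl, remains apart, and this holds against the new group as well (a 3.9-fold higher number from compound 2 to compound 4 (0.59 log units; beyond the scatter)).

Nothing shown here accounts for why these three groups give such similar numbers. Going by these compounds, whether an amine or a carboxylic acid on this carbon would also stay within the scatter remains open, as does whether any group there could reach the number of compound 2.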